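Compound 3: Benzyl in Place of Phenyl

The compounds below may be only part of what the source reports. "The series", "measured", "known", "first", "only" and "open" are said of these compounds alone.

Of the compounds shown here, two built on a shared core have been measured so far. In an ADME assay on HepG2 cells (Homo sapiens) for cytotoxicity, read by MTT assay (on this read-out lower numbers stand for stronger inhibition and higher numbers for weaker inhibition), compound 1 (`O=C(NC1CCCCC1)Oc1ccccc1C(=O)Nc1ccccc1`) gives 49000 nM, and compound 2 (`O=C(Nc1ccccc1)Oc1ccccc1C(=O)Nc1ccccc1`) gives 57700 nM. These two values lie within the scatter of each other, so compound 2 stands level with compound 1 and the pair cannot be ranked.

The next compound, compound 3 (`O=C(NCc1ccccc1)Oc1ccccc1C(=O)Nc1ccccc1`), changes compound 2 in one place, on an amide-type nitrogen, with benzyl in place of phenyl on an amide-type nitrogen. The same difference can be read as anilino to benzylamino.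

Within the data shown here, only one measured step bears on this change, phenyl in place of cyclohexyl on an amide-type nitrogen, which gave a 1.2-fold higher number from compound 1 to compound 2 (0.07 log units; within the scatter). That single step is thin evidence, but it offers no ground for expecting a large move in this assay. The expected result is a 1.0-fold lower number from compound 2 to compound 3 (0.02 log units; within the scatter), which amounts to no step beyond the scatter. For compound 3 the estimate is 55000 nM, with an expected range of 27000 nM to 110000 nM.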

Compound 3, half-maximal inhibitory concentration: > 125000 nM
Compound 3: no number, only a limit (the forecaster's own chance of this, stated with the estimate: 12%); middle value at least 2.2-fold (0.35 log units) from the limit.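

In this assay compound 3 gives no number but a limit of the assay: the limit of > 125000 nM in this assay, at which 1 of the 3 values shown sits. Even so, the limit is enough to place it, for benzyl on the amide-type nitrogen gives an at least 2.1-fold higher number from compound 2 to compound 3 (0.33 log units; beyond the scatter) and, set against cyclohexyl at the same place, an at least 2.5-fold higher number from compound 1 to compound 3 (0.40 log units; beyond the scatter). The earlier exchange gave only a 1.2-fold higher number from compound 1 to compound 2 (0.07 log units; within the scatter), so this position, which had looked indifferent to the choice between cyclohexyl and phenyl, does respond to the group placed on it, and it does so to benzyl even though benzyl keeps the six-membered aromatic ring of phenyl.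

On these data alone, how large the step to compound 3 really is stays open, since a limit fixes only one side of it. Also open, as far as these compounds go, is whether the trend would carry on to a longer chain such as phenethyl, or whether a carboxylic acid or an amine on the benzyl ring would bring the number back within reach of the assay.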